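The source may hold more compounds than are shown below. What is called first, only, known or untested is meant among the compounds shown, and "the series" means these compounds.

- compound 1 `CCOC(=O)c1c(C)nc(-c2cccc(C#N)c2)n1OC(C)C` gives 6740 nM in a functional assay on a cell-free system (plasma, Oryctolagus cuniculus) for inhibition, with stated times of 5 min, 1 min and 6 min; on this read-out lower numbers stand for stronger inhibition and higher numbers for weaker inhibition
- compound 2 `CCOCCOn1c(-c2cccc(C#N)c2)nc(C)c1C(=O)OCC` gives 6250 nM in this assay
- compound 3 `CCOC(=O)COn1c(-c2cccc(C#N)c2)nc(C)c1C(=O)OCC` gives 6800 nM in this assay

Compound 3 stands level with the other two compounds, and its steps are a 1.0-fold higher number from compound 1 to compound 3 (0.00 log units; within the scatter) and a 1.1-fold higher number from compound 2 to compound 3 (0.04 log units; within the scatter) on this read-out. The remaining measured step is a 1.1-fold lower number from compound 1 to compound 2 (0.03 log units; within the scatter) and it too lies within the scatter. All three steps concern the group on the oxygen, so they are the ones that bear on the next change. Isopropyl, 2-ethoxyethyl and (ethoxycarbonyl)methyl show no separation, and no measured compound goes against that.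

Compound 4 `CCOC(=O)c1c(C)nc(-c2cccc(C#N)c2)n1OCc1ccccc1` differs from compound 3 as follows: phenyl in place of ethoxycarbonyl on a saturated chain carbon bound to an oxygen on an aromatic ring with phenyl in place of ethoxycarbonyl on a saturated chain carbon bound to an oxygen on an aromatic ring. Within the data shown here, none of the measured compounds has phenyl at this place, so the change is not tested directly and the range has to stay wide.

Resting on the step of a 1.1-fold higher number from compound 2 to compound 3 (0.04 log units; within the scatter) at this same place, no step beyond the scatter is expected in this assay and no direction is favoured. The estimated step is a 1.1-fold lower number from compound 3 to compound 4 (0.03 log units; within the scatter) on this reasoning. For compound 4 the estimated value is 6300 nM with an expected range from 2500 nM to 14000 nM overall.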

Compound 4, half-maximal inhibitory concentration: 5930 nM
Compound 4: middle estimate off by 1.1-fold (0.03 log units), on the high side, and the stated range covers the measured number.
By their numbers in this assay, from the lowest: compounds 4, 2, 1 and 3 (each within the scatter of the next).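

Benzyl brings the first aromatic ring to the group on this oxygen, and in this assay it does not separate from the three groups without one. This holds for phenyl in place of ethoxycarbonyl (a 1.1-fold lower number from compound 3 to compound 4 (0.06 log units; within the scatter)), for phenyl in place of ethoxymethyl (a 1.1-fold lower number from compound 2 to compound 4 (0.02 log units; within the scatter)) and for benzyl in place of isopropyl (a 1.1-fold lower number from compound 1 to compound 4 (0.06 log units; within the scatter)), and no compound shown goes against it. Nothing available gives a reason for this flat picture.

Still open is whether an amine or a carboxylic acid on this oxygen, or a chain longer than those shown, would separate from these four compounds in this assay. Also open, from the compounds shown here alone, is what the ethoxycarbonyl and nitrile groups on the shared core contribute, as both stay the same throughout the four compounds.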